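The source may report more compounds than this note shows. Statements on the series, on what has been measured and on what is new or still open speak of the compounds shown alone.

Measured compounds:
- compound 1, `CCCCNc1nc(N)c2ncn([C@@H]3O[C@H](COP(=O)(O)OP(=O)(O)OP(=O)(O)O)[C@@H](O)[C@H]3O)c2n1`: 39 nM in an assay on cell membranes with P2Y purinoceptor 1 (Meleagris gallopavo) as the target; a higher number here means that more compound is needed for the effect, a lower number that less compound is needed
- compound 2, `CCCCOc1nc(N)c2ncn([C@@H]3O[C@H](COP(=O)(O)OP(=O)(O)OP(=O)(O)O)[C@@H](O)[C@H]3O)c2n1`: 88 nM in this assay
- compound 3, `CCCCSc1nc2c(N)ncnc2n1[C@@H]1O[C@H](COP(=O)(O)OP(=O)(O)OP(=O)(O)O)[C@@H](O)[C@H]1O`: 10000 nM in this assay

Compound 3 stands highest of the three numbers in this assay; compound 2 is nearest, and the gap between compound 3 and compound 2, and the wider one between compound 3 and compound 1, both lie well beyond the scatter.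

Compound 4, `CCCCOc1nc2c(N)ncnc2n1[C@@H]1O[C@H](COP(=O)(O)OP(=O)(O)OP(=O)(O)O)[C@@H](O)[C@H]1O`, is not yet measured. Its change from compound 3 is butoxy in place of butylsulfanyl on an aromatic carbon.

Among the measured compounds shown here, the only measured step is a 2.3-fold higher number from compound 1 to compound 2 (0.35 log units; beyond the scatter): there, butoxy in place of butylamino cost a modest amount. That step sits on a different carbon and swaps an oxygen for a nitrogen, not for a sulfur, so it bears on the present change only loosely. For the measured compounds named here, no step in this set shows oxygen in place of sulfur at any position, and no step shows any change on the five-membered ring. The expectation for compound 4 is therefore no step beyond the scatter, with wide uncertainty in either direction: a 1.4-fold lower number from compound 3 to compound 4 (0.15 log units; within the scatter). Compound 4 is estimated at 7000 nM, with a range from 1500 nM to 30000 nM.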

Compound 4, half-maximal effective concentration: 5710 nM
Compound 4: the middle estimate sits 1.2-fold (0.09 log units) above what was measured, and the stated range covers the measured number.
By their numbers in this assay, from the lowest: compound 1; then compound 2; then compounds 4 and 3 (each within the scatter of the next).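

In this assay the change from butylsulfanyl to butoxy on this aromatic carbon of the five-membered ring gives a 1.8-fold lower number from compound 3 to compound 4 (0.24 log units; within the scatter) and so cannot be told apart from no change. At this position the number therefore does not depend on whether sulfur or oxygen links the butyl chain to the ring, and the high number of compound 3 is not particular to its sulfur, since compound 4 with its oxygen gives 5710 nM in this assay as well. Among the compounds shown here, the only other swap of a linking atom, butoxy for butylamino, gives a 2.3-fold higher number from compound 1 to compound 2 (0.35 log units; beyond the scatter) and is a modest step beyond the scatter, while the new step is the first to show a swap at this position that stays within it. Nothing at hand offers a measured reason for either step.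

Still open, on these data alone, is whether butylamino on this same carbon would stay level with butoxy and butylsulfanyl, which would show whether the insensitivity extends to a nitrogen link. Also open, as far as these compounds go, is whether a different group here, such as a hexyl chain, a phenyl ring or a butyl chain ending in a carboxylic acid, would move the number beyond the scatter.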